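A few compounds are considered here, and "the series" means these few. Any claim that something is new, unique, unknown or untested is made for them only; others in the source may bear on it.

Of the compounds shown here, three sharing one core have been measured in a functional assay on MCF7 cells (Homo sapiens) for cytotoxicity, read by MTT assay, with a stated time of 72 h; on this read-out higher numbers stand for weaker inhibition and lower numbers for stronger inhibition. Compound 1 `CN(C)c1ccc(C=C2C(=O)N(c3ccc(Cl)cc3)N(c3ccc(Cl)cc3)C2=O)cc1` returns only a limit, > 128000 nM. Compound 2 `O=C1C(=Cc2ccc(Br)cc2)C(=O)N(c2ccc(Cl)cc2)N1c1ccc(Cl)cc1` returns a number, 30400 nM. Compound 3 `O=C1C(=Cc2ccc(Cl)cc2Cl)C(=O)N(c2ccc(Cl)cc2)N1c1ccc(Cl)cc1` also returns only a limit, > 128000 nM. This is the limit of > 128000 nM in this assay, at which 2 of the 3 values shown sit.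

The next compound, compound 4 `O=C1C(=Cc2ccc(F)cc2F)C(=O)N(c2ccc(Cl)cc2)N1c1ccc(Cl)cc1`, carries 2,4-difluorophenyl in place of 2,4-dichlorophenyl on a double-bonded chain carbon bound to a double-bonded ring carbon.

Two measured steps change the group at this place and can be read. The step of an at least 4.2-fold higher number from compound 2 to compound 3 (0.62 log units; beyond the scatter) brings in the 2,4-dichlorophenyl group, and the step of an at least 4.2-fold lower number from compound 1 to compound 2 (0.62 log units; beyond the scatter) shows that a change on this same aromatic group can also move the number. The step that the two limits leave unreadable from compound 1 to compound 3 cannot be sized, as both ends are limits. Neither step tests fluorine, so only a modest move towards a lower number is expected, and another limit remains quite possible.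

For compound 4 the estimated value is 70000 nM, with an expected range from 22000 nM to 150000 nM. The expected step is an at least 1.8-fold lower number from compound 3 to compound 4 (0.26 log units; that floor lies within the scatter).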

Compound 4, half-maximal inhibitory concentration: 22000 nM
Estimate against measurement, compound 4: 3.2-fold (0.50 log units) above, within the range that was stated.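

In this assay, exchanging 2,4-dichlorophenyl for 2,4-difluorophenyl on a double-bonded chain carbon bound to a double-bonded ring carbon gives an at least 5.8-fold lower number from compound 3 to compound 4 (0.76 log units; beyond the scatter), so at this place the identity of the halogen alone can bring a number out from the limit. The 4-bromophenyl and 2,4-difluorophenyl groups cannot be told apart, with a 1.4-fold lower number from compound 2 to compound 4 (0.14 log units; within the scatter), while an at least 5.8-fold lower number from compound 1 to compound 4 (0.76 log units; beyond the scatter) shows 2,4-difluorophenyl also clear of the 4-(dimethylamino)phenyl compound. These steps have only a floor for their size, as two compounds end at a limit rather than a number: the limit of > 128000 nM in this assay, at which 2 of the 4 values shown sit.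

The compounds shown leave open whether both fluorines are needed, which a 4-fluorophenyl or 2-fluorophenyl group at this place would test. They also leave open how a methoxy group or a carboxylic acid on this ring would read.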